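The source may hold more compounds than are shown below. What is called first, only, known or untested is meant among the compounds shown, and "the series" means these compounds.

Measured in a physicochemical assay for lipophilicity, at pH 7.4; on this read-out lower numbers stand for lower lipophilicity and higher numbers for higher lipophilicity:
- compound 1 `CCS(=O)(=O)c1ccc2c(c1)C=CN(C)C(=O)[C@@H]2C`: 3.1
- compound 2 `CCS(=O)(=O)c1ccc2c(c1)C(C)=CN(C)C(=O)[C@@H]2C`: 3.4
- compound 3 `CCS(=O)(=O)c1ccc2c(c1)C(C(N)=O)=CN(C)C(=O)[C@@H]2C`: 1.1

The three compounds differ only in the group on one double-bonded ring carbon of the shared core. On this assay, compound 3, which carries carbamoyl there, stands lowest at 1.1, and its steps to both of the others lie beyond the scatter.

Compound 4 `CCS(=O)(=O)c1ccc2c(c1)C(c1cnn(C)c1)=CN(C)C(=O)[C@@H]2C` has 1-methyl-1H-pyrazol-4-yl in place of carbamoyl on that same carbon: 1-methyl-1H-pyrazol-4-yl in place of carbamoyl on a double-bonded ring carbon.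

Among the compounds with values here, three measured steps bear on this change. The two that introduce carbamoyl are both large: a number 2.00 log units lower from compound 1 to compound 3 (beyond the scatter) and a number 2.30 log units lower from compound 2 to compound 3 (beyond the scatter). The exchange of hydrogen for methyl is small by comparison, at a number 0.30 log units higher from compound 1 to compound 2 (within the scatter). Compounds 1 and 2 thus give similar values with either of two groups that are not carbamoyl, and compound 4 also lacks carbamoyl. Within the data shown here, no measured compound has an aromatic ring on this carbon, however, so that part of the comparison remains untested and the range must stay wide. The step expected is therefore large and upward, an estimated a number 1.80 log units higher from compound 3 to compound 4 (beyond the scatter). Compound 4 is expected at 2.9, with an estimated range of 2.4 to 3.4.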

Compound 4, distribution coefficient: 2.8
Compound 4: middle estimate off by 0.10 log units, on the high side; low and high end bracket the measured number.
By their numbers in this assay, from the lowest: compound 3; then compounds 4, 1 and 2 (each within the scatter of the next, the first and the last beyond it).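

In this assay, within the data shown here, an aromatic ring on this double-bonded ring carbon now has a measured value, and the exchange of carbamoyl for 1-methyl-1H-pyrazol-4-yl gives a number 1.70 log units higher from compound 3 to compound 4 (beyond the scatter) in the same large range as the steps that remove carbamoyl from the earlier compounds. Set against hydrogen, the ring gives a number 0.30 log units lower from compound 1 to compound 4 (within the scatter) so the two groups cannot be told apart on this read-out, while set against methyl it gives a number 0.60 log units lower from compound 2 to compound 4 (beyond the scatter) which is the first separation beyond the scatter among the groups other than carbamoyl on this carbon. Carbamoyl therefore remains the one group of the four that stands apart from each of the others by a large step.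

The compounds shown leave open whether a phenyl ring, a pyrazole without its methyl group, a carboxylic acid or an aminomethyl group on this carbon would fall with carbamoyl or with the other three. Nothing measured here accounts for why the numbers fall as they do.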